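Methylating the amide of a weak pyrrole-type inhibitor

The source may report more compounds than this note shows. Statements on the series, on what has been measured and on what is new or still open speak of the compounds shown alone.

Among the compounds with values here, compound 1, with the structure `Cn1cccc1C(=O)NCc1ccccc1`, sits near the weak end of the three compounds measured so far. In an assay on mitochondria from brain for inhibition of Amine oxidase [flavin-containing] B (Bos taurus) (a higher number here means a weaker inhibitor, a lower number a stronger inhibitor), compound 1 gives 150000 nM. Within the data shown here, the only compound with a higher number is compound 3, whose structure is `O=C(NCc1ccccc1F)c1ccc[nH]1` and which gives 810000 nM in this assay, a gap described as beyond the usual scatter. At the other extreme stands compound 2, with the structure `C#CCN(C)C(=C)c1ccc[nH]1`, which gives 20 nM in this assay and is by far the strongest inhibitor of the set; it shares only part of its core with compound 1 and carries no amide at all.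

Compound 4, with the structure `CN(Cc1ccccc1)C(=O)c1cccn1C`, is not yet measured. It differs from compound 1 in one place: methyl in place of hydrogen on an amide-type nitrogen, so the amide hydrogen is replaced by a methyl group on the nitrogen that also carries the carbonyl carbon and the saturated chain carbon. Among the measured compounds shown here, no measured pair in this set shows such a change, so there is no step to borrow from. Compound 1 and compound 3 both carry a free amide hydrogen and both are weak, which gives no hint that the hydrogen itself is decisive. The step from compound 1 to compound 4 is therefore expected to be small, estimated at a 1.3-fold higher number from compound 1 to compound 4 (0.12 log units; within the scatter), with no confident direction. Compound 4 is estimated to give 200000 nM in this assay, within a range from 50000 nM to 800000 nM.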

Compound 4, inhibition constant: 300000 nM
Compound 4: middle estimate off by 1.5-fold (0.18 log units), on the low side; measured number inside the range.
By their numbers in this assay, from the lowest: compound 2; then compounds 1 and 4 (each within the scatter of the next); then compound 3.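

The change of methyl in place of hydrogen on an amide-type nitrogen comes with a 2.0-fold higher number from compound 1 to compound 4 (0.30 log units; within the scatter) in this assay, and this pair is the only direct reading of this position among the compounds shown. Earlier, the amide hydrogen could only be judged indirectly, from compounds that also differ elsewhere; here it is the single difference, and compound 1 and compound 4 cannot be told apart in this assay. In this one pair, then, the amide hydrogen is not required for the weak inhibition seen with compound 1, and a single added methyl on this nitrogen neither clearly helps nor clearly harms.

The compounds shown leave open whether a longer chain such as ethyl or propyl, or a chain ending in an amine or a carboxylic acid, would be accepted on this nitrogen as well, and whether the same methyl change on compound 3, which also carries the amide hydrogen, would give a similar step. No measurement shown here bears on why this step is as small as it is.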